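The compounds below may be only part of what the source reports. "The series", "measured", "known", "first", "only" and "open" are said of these compounds alone.

Measured so far in a functional assay on U-937 cells (Homo sapiens) for cytotoxicity, read by CCK-8 assay, with a stated time of 72 h; on this read-out higher numbers stand for weaker inhibition and lower numbers for stronger inhibition:
compound 1, `COc1ccccc1/C=c1/[nH]c(=O)/c(=C\c2ccccc2OC)[nH]c1=O` — "not active" (no number reported)
compound 2, `C=CCn1c(=O)/c(=C\c2cc(F)ccc2C)[nH]c(=O)/c1=C\c1ccccc1OC` — 1000 nM
compound 3, `C=CCn1c(=O)/c(=C\c2ccc(F)c(Br)c2)[nH]c(=O)/c1=C\c1ccccc1OC` — "not active" (no number reported)

Compound 3 stands without a single number: in this assay compound 3 is reported only as "not active" (no number reported), and compound 1 is likewise reported only as "not active" (no number reported). Among the compounds with values here, the one compound of the set with a number is compound 2, which in this assay gives 1000 nM. Within the data shown here, no step between measured compounds is available, so nothing about the size of a change can be read off directly.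

Compound 4, `C=CCn1c(=O)/c(=C\c2ccccc2OC)[nH]c(=O)/c1=C\c1ccccc1OC`, is to be measured in this assay. Its change from compound 3 is 2-methoxyphenyl in place of 3-bromo-4-fluorophenyl on a double-bonded chain carbon bound to an aromatic carbon. Compound 4 then carries the same 2-methoxyphenyl group on both double-bonded chain carbons, as compound 1 does, while keeping the allyl group that compound 2 carries. Compound 1 gave no number, compound 2 did; the expectation for compound 4 is therefore uncertain, and a result as a limit rather than a number is quite possible. Compound 4 is estimated at 3000 nM, with a range from 700 nM to 20000 nM.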

Compound 4, half-maximal inhibitory concentration: 5100 nM
The estimate for compound 4 lay 1.7-fold (0.23 log units) below the measured number, within the range that was stated.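

In this assay the group on a double-bonded chain carbon bound to an aromatic carbon now shows a measurable effect: 2-methoxyphenyl in place of 5-fluoro-2-methylphenyl gives a 5.1-fold higher number from compound 2 to compound 4 (0.71 log units; beyond the scatter) at this place. Compound 3 is reported as "not active" (no number reported) while compound 4 gives 5100 nM with 2-methoxyphenyl in place of 3-bromo-4-fluorophenyl, so 2-methoxyphenyl falls between the other two groups in the reading, although no size can be read for the step from compound 3. No measurement bearing on the reason for either difference is available.

Which substituent on these aromatic rings carries the differences remains open, since the three groups shown differ in more than one substituent. Also open, from the compounds shown here alone, is how an aryl group bearing an amine or a carboxylic acid at this place would read in this assay for the allyl compounds.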